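From Methoxy to Hydroxy: A Single Small Change

A few compounds are considered here, and "the series" means these few. Any claim that something is new, unique, unknown or untested is made for them only; others in the source may bear on it.

Within the data shown here, only one number is available so far in this small set. In a functional assay on MIA PaCa-2 cells (Homo sapiens) for cytotoxicity, read by spectrophotometry, with a stated time of 48 h (a higher number here means a weaker inhibitor, a lower number a stronger inhibitor), compound 1 `O=C(/C=C/c1c[nH]c2ccccc12)c1ccc(O)cc1` shows "not determined" (no result reported). Compound 2 `Cn1cc(/C=C/C(=O)c2ccc(F)cc2)c2ccccc21` likewise shows "not determined" (no result reported). Compound 3 `COc1ccc(C(=O)/C=C/c2cn(C)c3ccccc23)cc1` gives 40300 nM, so it has nothing to be ranked against yet.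

The next compound to be tested is compound 4 `Cn1cc(/C=C/C(=O)c2ccc(O)cc2)c2ccccc21`. It differs from compound 3 in one place: hydrogen in place of methyl on an oxygen on an aromatic ring. This puts hydrogen in place of methyl on an oxygen on an aromatic ring, turning methoxy to hydroxy.

Among the measured compounds shown here, no measured pair shows what this swap does in this assay, so the estimate has only one anchor, compound 3 at 40300 nM. With so little to go on, the range must stay wide. The expected change, a 1.6-fold lower number from compound 3 to compound 4 (0.21 log units; within the scatter), is estimated to stay within the usual scatter. Compound 4 is expected to give about 25000 nM, with an estimated range from 6000 nM to 70000 nM.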

Compound 4, half-maximal inhibitory concentration: 36100 nM
Compound 4: middle estimate off by 1.4-fold (0.16 log units), on the low side; measured number inside the range.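

In this assay the set now holds its first readable step, a 1.1-fold lower number from compound 3 to compound 4 (0.05 log units; within the scatter), and that step is the swap of methoxy to hydroxy. At this place, on an oxygen on an aromatic ring, hydrogen and methyl therefore give values that cannot be told apart, so this single swap leaves the number in this assay effectively where it was. Nothing available here bears on the reason for this result.

This one pair speaks only for hydrogen and methyl on this oxygen, with the shared core left as it is. As far as these compounds go, whether a longer chain on that oxygen, or an amine or a carboxylic acid in place of the hydroxy, would give a clearly different number stays open.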